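Notes on an amide nitrogen change in the series

The compounds below may be only part of what the source reports. "The series", "measured", "known", "first", "only" and "open" are said of these compounds alone.

Compound 1 `CC[C@@H]1C(=O)N(C)c2cnc(-n3ccc4cc(C(N)=O)ccc43)nc2N1C1CCCC1` is the reference point here. In an assay for inhibition of serine/threonine-protein kinase PLK2 (Homo sapiens), read by FRET and Z'-LYTE, with a stated time of 1 h (on this read-out lower numbers stand for stronger inhibition and higher numbers for weaker inhibition), compound 1 gives 28.5 nM. Two other members carry the same core. Compound 3 `CCCCNS(=O)(=O)c1ccc(Nc2ncc3c(n2)N(C2CCCC2)[C@H](CC)C(=O)N3C)cc1` gives 19.9 nM in this assay, a number that sits within the scatter of compound 1. Compound 2 `CCCNS(=O)(=O)c1ccc(Nc2ncc3c(n2)N(c2ccn(C)n2)C(CC)C(=O)N3C)cc1` gives 190 nM in this assay, a higher number than compound 1 and beyond the scatter. Compound 1 therefore holds the second highest number of the three. Compound 4 `CC[C@@H]1C(=O)N(C)c2cnc(-n3ccc4cc(C(=O)NC(C)C)ccc43)nc2N1C1CCCC1` differs from compound 1 by isopropyl in place of hydrogen on an amide-type nitrogen. Going by the values given here, no measured pair shows this change, so its size is unknown from the data; the step of a 1.1-fold higher number from compound 1 to compound 4 (0.05 log units; within the scatter) is expected to remain within the scatter, with no clear direction. Compound 4 is estimated at 32 nM, with a range from 12 nM to 85 nM.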

Compound 4, half-maximal inhibitory concentration: 17.4 nM
The estimate for compound 4 lay 1.8-fold (0.26 log units) above the measured number; the range from low to high includes it.
By their numbers in this assay, from the lowest: compounds 4, 3 and 1 (each within the scatter of the next); then compound 2.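

In this assay, going by these compounds alone, the first measured pair at this amide-type nitrogen gives a 1.6-fold lower number from compound 1 to compound 4 (0.21 log units; within the scatter) for isopropyl in place of hydrogen, so the change shows no clear direction. The amide hydrogen is therefore not needed to keep compound 4 within the scatter of compound 1 in this assay. Nothing available bears on the origin of this result.

Still open, from the compounds shown here alone, is whether a longer chain, or a chain ending in an amine, on this nitrogen would also stay within the scatter of compound 1.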